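The source may report more compounds than this note shows. Statements on the series, on what has been measured and on what is new or still open speak of the compounds shown alone.

Of the compounds shown here, three that share one core have been tested in a functional assay on HeLa cells (Homo sapiens) for cytotoxicity, in the presence of a further agent that is not named here; a lower number here means a stronger inhibitor, a higher number a weaker inhibitor. Compound 1 `Clc1ccc(-c2cc(-c3ccc(Cl)o3)cc(-c3cccs3)n2)cc1` gives 21300 nM in this assay. Compound 2 `Cc1cccc(-c2cc(-c3ccc(Cl)o3)cc(-c3ccsc3)n2)c1` gives 20300 nM in this assay. Compound 3 `Clc1ccc(-c2cc(-c3ccoc3)cc(-c3ccsc3)n2)cc1` gives 4140 nM in this assay, the lowest of the three numbers; the nearest of the others, compound 2, lies beyond the scatter, and compound 1 lies a little further still. Compound 4 `Clc1ccc(-c2cc(-c3ccc(Cl)o3)cc(-c3ccsc3)n2)cc1` has not yet been measured. It differs from compound 3 in one place: 5-chlorofuran-2-yl in place of furan-3-yl on an aromatic carbon. Among the compounds with values here, no pair of measured compounds shows this change on its own, so its size cannot be read off directly. What the numbers do show is that compound 1 and compound 2, which both carry the 5-chlorofuran-2-yl group, give the two higher values, whereas compound 3, which carries furan-3-yl, gives the lowest, although those compounds also differ from one another elsewhere. On that basis the step in this assay is expected to go towards a higher number, beyond the scatter, and is estimated at a 3.4-fold higher number from compound 3 to compound 4 (0.53 log units; beyond the scatter). Compound 4 is accordingly expected to give about 14000 nM in this assay, within a range from 5000 nM to 40000 nM.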

Compound 4, half-maximal inhibitory concentration: 8410 nM
The estimate for compound 4 lay 1.7-fold (0.22 log units) above the measured number; the measured number falls inside the stated range.
By their numbers in this assay, from the lowest: compound 3; then compound 4; then compounds 2 and 1 (each within the scatter of the next).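

In this assay, the change from furan-3-yl to 5-chlorofuran-2-yl on the aromatic carbon opposite the ring nitrogen now has a size of its own: a 2.0-fold higher number from compound 3 to compound 4 (0.31 log units; beyond the scatter), a modest step beyond the scatter, with furan-3-yl giving the lower number of the two. Compound 4 also connects this series in the other two places while 5-chlorofuran-2-yl stays fixed: 4-chlorophenyl in place of 3-methylphenyl gives a 2.4-fold lower number from compound 2 to compound 4 (0.38 log units; beyond the scatter), and thiophen-3-yl in place of thiophen-2-yl gives a 2.5-fold lower number from compound 1 to compound 4 (0.40 log units; beyond the scatter). Each of these three changes, taken alone, is modest, and nothing available here accounts for any of them.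

The step from furan-3-yl to 5-chlorofuran-2-yl combines two differences, the chlorine and the point of attachment of the furan, and the compounds shown do not separate them. How this position would respond to an amine, a carboxylic acid or a longer chain in place of the furan also remains open, as every compound shown carries a furan there.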